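The compounds below may be only part of what the source reports. "The series", "measured", "known", "first", "only" and "open" are said of these compounds alone.

Measured in an ADME assay on HEK293 cells (Homo sapiens) for cytotoxicity, read by CCK-8 assay, with a stated time of 48 h; on this read-out higher numbers stand for weaker inhibition and lower numbers for stronger inhibition:

- Compound 1 `COc1ccc(/C=C\c2cc(OC)c(OC)c(OC)c2)cc1OCc1ccc(CO)cc1`: 37000 nM
- Compound 2 `COc1ccc(/C=C\c2cc(OC)c(OC)c(OC)c2)cc1OCc1ccc(CN2CCCCC2C(=O)NCCN)cc1`: > 50000 nM

Compound 2 has no number of its own in this assay: its > 50000 nM is a limit of the assay. The evidence so far is correspondingly thin: the limit of > 50000 nM in this assay, at which 1 of the 2 values shown sits.

Compound 3 `COc1ccc(/C=C\c2cc(OC)c(OC)c(OC)c2)cc1OCc1ccc(CN[C@H](C(=O)O)[C@@H](C)O)cc1` keeps the shared core and carries (1-carboxy-2-hydroxypropyl)amino in place of 2-((2-aminoethyl)carbamoyl)piperidin-1-yl on a saturated chain carbon bound to an aromatic carbon.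

Within the data shown here, only one measured step bears on this place. It is an at least 1.3-fold higher number from compound 1 to compound 2 (0.13 log units; that floor lies within the scatter), which brought in the group that compound 3 gives up. Going by these compounds, its true size is unknown, and its floor lies within the scatter. Among the measured compounds shown here, the only actual number at this place remains that of compound 1, at 37000 nM. No step beyond the scatter is therefore expected in this assay, and a further reading at the limit would be no surprise. The expected step is a number no higher from compound 2 to compound 3 (the limit leaves the size open). For compound 3 the estimated value is 50000 nM, with an expected range from 25000 nM to 100000 nM.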

Compound 3, half-maximal inhibitory concentration: > 50000 nM
Compound 3: only a limit was reported; the forecaster's own chance of this, stated with the estimate: 55%; the middle value lies on the limit itself.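

In this assay compound 3 gives > 50000 nM, which is a limit of the assay and not a number. On a saturated chain carbon bound to an aromatic carbon, the open-chain (1-carboxy-2-hydroxypropyl)amino group in place of hydroxy gives an at least 1.3-fold higher number from compound 1 to compound 3 (0.13 log units; that floor lies within the scatter), so a second, quite different group now yields only a floor that does not clear the scatter. The step from compound 2 to compound 3 cannot be read, and the limit now holds most of what is shown at this place: the limit of > 50000 nM in this assay, at which 2 of the 3 values shown sit.

Going by these compounds, the actual numbers for compound 2 and compound 3 stay open, and so does whether any replacement of hydroxy at this place moves the reading beyond the scatter. Nor do the compounds shown tell how a morpholin-4-yl group or a plain carboxylic acid on the same carbon would read in this assay, or whether either would give a number rather than a limit.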